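The compounds below may be only part of what the source reports. "The series", "measured", "known", "first", "only" and "open" are said of these compounds alone.

Working notes on the series. Going by the values given here, compound 3 `COc1ccc(S(=O)(=O)c2c(C)cc(C)cc2C)cc1` is the only member with a number: in an assay on isolated protein for antagonist activity at Rap guanine nucleotide exchange factor 4 (Homo sapiens), read by fluorescence and cAMP accumulation (on this read-out lower numbers stand for stronger inhibition and higher numbers for weaker inhibition), compound 3 gives 1900 nM. Compound 1 `CCCCCc1ccc(S(=O)(=O)c2c(C)cc(C)cc2C)cc1` reaches only a limit in this assay, > 300000 nM. Compound 2 `Cc1cc(C)c(S(=O)(=O)c2ccc(C3CCCCC3)cc2)c(C)c1` likewise stops at a limit in this assay, > 300000 nM. Both sit at the same limit, (the limit of > 300000 nM in this assay, at which 2 of the 3 values shown sit), and for that reason the step that the two limits leave unreadable from compound 1 to compound 2 cannot be read. Against them, an at least 150-fold lower number from compound 1 to compound 3 (2.19 log units; beyond the scatter) and an at least 150-fold lower number from compound 2 to compound 3 (2.19 log units; beyond the scatter) are both large drops in the number.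

Compound 4 `Cc1cc(C)c(S(=O)(=O)c2ccc(OC3CCCCC3)cc2)c(C)c1` differs from compound 3 in one place: cyclohexyl in place of methyl on an oxygen on an aromatic ring. Among the compounds with values here, the measured step that bears on it is an at least 150-fold lower number from compound 2 to compound 3 (2.19 log units; beyond the scatter), read backwards: compound 2 carries a cyclohexyl on the shared core and sits at a limit, while compound 3 carries a methoxy and gives the only number. Compound 4 places a cyclohexyl on that oxygen instead. A large rise in the number is therefore expected, a 53-fold higher number from compound 3 to compound 4 (1.72 log units; beyond the scatter), with a fair chance that only a limit is reported. Compound 4 is expected to give 100000 nM in this assay, between 10000 nM and 1000000 nM.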

Compound 4, half-maximal inhibitory concentration: > 300000 nM
Compound 4 gave a limit, no number (the forecaster's own chance of this, stated with the estimate: 55%); at least 3.0-fold (0.47 log units) between middle value and limit.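

Cyclohexyl in place of methyl on the oxygen gives an at least 150-fold higher number from compound 3 to compound 4 (2.19 log units; beyond the scatter), so this change alone, with the oxygen kept on the aromatic ring, is enough to lose the measurable number in this assay. The earlier compounds shown here replaced the whole methoxy with a carbon-linked group, whereas this step shows that the oxygen by itself does not preserve a number once it carries cyclohexyl. The steps from compound 1 and from compound 2 to compound 4 cannot be read: the limit of > 300000 nM in this assay, at which 3 of the 4 values shown sit.

The compounds shown leave open whether a number survives with a group on the oxygen of intermediate size, such as ethyl or isopropyl. They also leave open whether a hydroxyl or an amine in place of the methoxy would keep a number in this assay.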